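The source may report more compounds than this note shows. Statements on the series, on what has been measured and on what is new or still open speak of the compounds shown alone.

Measured so far:
compound 1 `CCOC(=O)/C(C#N)=C/c1cc(C)n(-c2cccc(-c3nnn[nH]3)c2)c1C` — 76800 nM
compound 2 `Cc1cc(/C=C2\SC(=S)N(c3ccccc3)C2=O)c(C)n1-c1cccc(-c2nnn[nH]2)c1` — 61000 nM

In an ADME assay on MT2 cells (Homo sapiens) for cytotoxicity, read by XTT assay, with a stated time of 4 days (on this read-out lower numbers stand for higher toxicity in this test and higher numbers for lower toxicity in this test), compound 1 gives 76800 nM and compound 2 gives 61000 nM. The two numbers lie within the scatter of each other, so compound 2 stands level with compound 1 on the numbers shown, and neither can be called the more or the less toxic of the pair.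

Compound 3 `COc1cccc(N2C(=O)/C(=C/c3cc(C)n(-c4cccc(-c5nnn[nH]5)c4)c3C)SC2=S)c1` has not yet been measured. Its difference from compound 2 is methoxy in place of hydrogen on an aromatic carbon. Going by the values given here, no step between measured compounds is available to set the size of such a change, so the expectation rests on compound 2 alone.

In this assay compound 3 is expected to land close to compound 2, with a step of a 1.2-fold lower number from compound 2 to compound 3 (0.09 log units; within the scatter) that is not expected to go beyond the scatter. The estimate for compound 3 is 50000 nM, with a range from 20000 nM to 120000 nM.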

Compound 3, half-maximal cytotoxic concentration: 40600 nM
Compound 3: middle estimate off by 1.2-fold (0.09 log units), on the high side; the measured number falls inside the stated range.
By their numbers in this assay, from the lowest: compounds 3, 2 and 1 (each within the scatter of the next).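

In this assay, methoxy in place of hydrogen on this aromatic carbon, meta to a large group, gives a 1.5-fold lower number from compound 2 to compound 3 (0.18 log units; within the scatter). Going by these compounds alone, the first reading at this position therefore shows that the change from phenyl to 3-methoxyphenyl leaves compound 3 level with compound 2 on this read-out, so this one group, with its single hydrogen-bond acceptor, does not separate the pair. The compounds shown offer no measurement that could account for this result.

Going by these compounds, whether an amine, a carboxylic acid or a longer chain such as butoxy at the same carbon would move the number beyond the scatter stays open. Also open, on these data alone, is whether methoxy on another carbon of this ring would read the same.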